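This account rests on a few compounds, and the source may have more. Where it says the series, first, only, none or still open, it means among the compounds named here.

Of the compounds shown here, three sharing one core have been measured in a physicochemical assay for lipophilicity, using the shake flask method, measured as octanol-water partition, at pH 7.4; a lower number here means a more polar compound, a higher number a more lipophilic compound. Compound 3 `CC(=O)N[C@@H]1CCC[C@H](C(=O)Nc2cc(-c3cnn4c3CCC4)c(Cl)cn2)C1` gives 2.9, compound 1 `CC(=O)N[C@@H]1CCC[C@H](C(=O)Nc2cc(-c3cnc4n3CCCC4)c(Cl)cn2)C1` gives 2.7 and compound 2 `CC(=O)N[C@@H]1CCC[C@H](C(=O)Nc2cc(-c3nnn4ccccc34)c(Cl)cn2)C1` gives 2. The data show a number 0.20 log units higher from compound 1 to compound 3 (within the scatter), so that pair cannot be separated, and they also show a number 0.90 log units higher from compound 2 to compound 3 (beyond the scatter).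

Compound 4 `CC(=O)N[C@@H]1CCC[C@H](C(=O)Nc2cc(-c3cnc4n3CCC4)c(Cl)cn2)C1` has the same atoms as compound 3, joined differently: a group of 8 heavy atoms (6 carbon, 2 nitrogen; one five-membered non-aromatic ring with 1 hetero atom, one five-membered aromatic ring with 2 hetero atoms) in place of a group of 8 heavy atoms (6 carbon, 2 nitrogen; one five-membered non-aromatic ring with 1 hetero atom, one five-membered aromatic ring with 2 hetero atoms), on an aromatic carbon. The site is opposite the ring nitrogen and ortho to a chloro group. Among the compounds with values here, no measured step is this exact exchange, so the evidence is indirect. The exchange closest in kind, with no six-membered aromatic ring entering, is a number 0.20 log units higher from compound 1 to compound 3 (within the scatter). The two steps involving the six-membered aromatic ring of compound 2 are larger, and one of them is a number 0.70 log units lower from compound 1 to compound 2 (beyond the scatter). Compound 4 gains no such ring, so a step of that full size is not expected. The direction is only weakly supported, with compound 1 at 2.7 as the nearest guide, and a small fall is expected. The expected change is a number 0.40 log units lower from compound 3 to compound 4 (beyond the scatter). For compound 4 the estimated value is 2.5, with an expected range from 2.1 to 2.9.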

Compound 4, distribution coefficient: 2.6
For compound 4 the middle estimate is 0.10 log units below the measured one, and the stated range covers the measured number.
By their numbers in this assay, from the lowest: compound 2; then compounds 4, 1 and 3 (each within the scatter of the next).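

In this assay, rejoining the same atoms within the group on this aromatic carbon, opposite the ring nitrogen and ortho to a chloro group, gives a number 0.30 log units lower from compound 3 to compound 4 (within the scatter), so the two arrangements cannot be separated, and the counts of heavy atoms, donors and acceptors stay unchanged across this exchange. Compound 4 also cannot be separated from the group with the six-membered non-aromatic ring, as shown by a number 0.10 log units lower from compound 1 to compound 4 (within the scatter), while the group with the six-membered aromatic ring stands apart, as shown by a number 0.60 log units higher from compound 2 to compound 4 (beyond the scatter); compounds 1, 3 and 4 therefore form one cluster, and compound 2 is the only compound outside it. Nothing measured here offers a reason for any of these steps.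

As far as these compounds go, how a hydroxyl group or a carboxylic acid on the five-membered non-aromatic ring would shift this number remains open, as does whether an amine there would keep a compound inside the cluster. From the compounds shown here alone, it is also open whether these steps would keep their size if a methoxy group or a fluorine took the place of the chloro group.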